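Amide aryl exchange from compound 2 to compound 3

The source may hold more compounds than are shown below. What is called first, only, known or untested is meant among the compounds shown, and "the series" means these compounds.

Measured so far:
compound 1 `O=C(Nc1c(C(O)(C(F)(F)F)C(F)(F)F)ccc2ccccc12)C1CCCC1` gives 495 nM in an assay on LtK cells with ATP-sensitive inward rectifier potassium channel 11 (Homo sapiens) as the target; on this read-out higher numbers stand for an effect only at larger amounts of compound and lower numbers for an effect already at smaller amounts
compound 2 `Cc1ccc(C(=O)Nc2c(C(O)(C(F)(F)F)C(F)(F)F)ccc3ccccc23)cc1` gives 76 nM in this assay

Among the measured compounds shown here, compound 2 holds the lowest of the two numbers in this assay; its only neighbour is compound 1, reached by a 6.5-fold lower number from compound 1 to compound 2 (0.81 log units; beyond the scatter). Compound 3 `O=C(Nc1c(C(O)(C(F)(F)F)C(F)(F)F)ccc2ccccc12)c1ccc(Cl)c(Cl)c1` differs from compound 2 by 3,4-dichlorophenyl in place of 4-methylphenyl on a carbonyl carbon. For the measured compounds named here, the one measured step at this position, a 6.5-fold lower number from compound 1 to compound 2 (0.81 log units; beyond the scatter), swapped a non-aromatic ring for an aromatic one, whereas here one six-membered aromatic ring of carbon only replaces another. Going by the values given here, no measured step covers that kind of exchange. Compound 3 is therefore expected to show a step of a 1.3-fold lower number from compound 2 to compound 3 (0.10 log units; within the scatter), within the scatter. Compound 3 is estimated at 60 nM, range 20 nM to 200 nM.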

Compound 3, half-maximal effective concentration: 194 nM
Beside the measured number, compound 3's estimate is 3.2-fold (0.51 log units) below it; the range from low to high includes it.
By their numbers in this assay, from the lowest: compound 2; then compound 3; then compound 1.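

Aryl exchange on the carbonyl carbon is not neutral in this assay, as 3,4-dichlorophenyl in place of 4-methylphenyl gives (a 2.6-fold higher number from compound 2 to compound 3 (0.41 log units; beyond the scatter)). Against cyclopentyl, 3,4-dichlorophenyl still gives (a 2.6-fold lower number from compound 1 to compound 3 (0.41 log units; beyond the scatter)), so both aromatic rings listed here sit lower than cyclopentyl, with no compound shown going against this. Nothing available accounts for the difference between the two aromatic groups. Still open, as far as these compounds go, is whether the chlorines or the loss of the methyl drives the step, and how a methoxy group or an amine on the phenyl ring would read.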